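Adding a Second Chlorine Where One Already Sits

The source may report more compounds than this note shows. Statements on the series, on what has been measured and on what is new or still open speak of the compounds shown alone.

Of the compounds shown here, three built on a shared core have been tested in a functional assay on A549 cells (Homo sapiens) for cytotoxicity, read by MTT assay, with a stated time of 72 h; a higher number here means a weaker inhibitor, a lower number a stronger inhibitor. Compound 1 `COc1cccc(/C=C2\CCC/C(=C\c3ccc(O)cc3)C2=O)c1OC` reaches only the limit of the assay, > 20000 nM. Compound 2 `COc1cccc(/C=C2\CCC/C(=C\c3cccc(Cl)c3Cl)C2=O)c1OC` likewise gives only a limit, > 20000 nM. The step that the two limits leave unreadable from compound 1 to compound 2 therefore has no readable size. Going by the values given here, compound 3 `COc1ccc(/C=C2\CCC/C(=C\c3cccc(Cl)c3)C2=O)cc1OC` is the one compound with a number: in this assay compound 3 gives 11000 nM. It stands alone, since the two other values are limits (the limit of > 20000 nM in this assay, at which 2 of the 3 values shown sit).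

Compound 4 `COc1ccc(/C=C2\CCC/C(=C\c3ccc(Cl)c(Cl)c3)C2=O)cc1OC` is still to be measured. It differs from compound 3 in one place: chloro in place of hydrogen on an aromatic carbon. The same difference, cut one bond further out, reads: 3-chlorophenyl to 3,4-dichlorophenyl. Among the compounds with values here, none of the measured steps bears on adding a chloro group in this way; the one step that exists, a step that the two limits leave unreadable from compound 1 to compound 2, joins two limits and gives no size at all. Within the data shown here, with no comparable step in hand, the expectation is a change no larger than the usual scatter, in no particular direction. The expected step of a 1.4-fold lower number from compound 3 to compound 4 (0.14 log units; within the scatter) is thus small. Compound 4 is estimated at 8000 nM, with a range from 3000 nM to 20000 nM, and a fair chance that the assay again returns only a limit.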

Compound 4, half-maximal inhibitory concentration: 6900 nM
Beside the measured number, compound 4's estimate is 1.2-fold (0.06 log units) above it; the range from low to high includes it.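

In this assay, going by these compounds alone, adding a chloro group to the 3-chlorophenyl ring gives a 1.6-fold lower number from compound 3 to compound 4 (0.20 log units; within the scatter), the first step with a readable size. It shows that chloro in place of hydrogen on this aromatic carbon, ortho to a chloro group and para to a large group, leaves the result indistinguishable from that of the single-chlorine compound, so 3-chlorophenyl and 3,4-dichlorophenyl cannot be told apart in this measurement. Compound 3 and compound 4 both give real numbers, which allows a size to be read here, whereas the other values give only the assay's limit: the limit of > 20000 nM in this assay, at which 2 of the 4 values shown sit.

The compounds shown leave open whether a different group on this same aromatic carbon, such as an amine or a carboxylic acid, would produce a step beyond the scatter. Within the data shown here, they also leave open whether adding this chloro group would give a similarly small step in another compound on the shared core, as this single pair is the only example of the change.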